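Ethoxy in place of isobutyl: an expected flat step

This account rests on a few compounds, and the source may have more. Where it says the series, first, only, none or still open, it means among the compounds named here.

Measured compounds in a functional assay on KB cells (Homo sapiens) for antiproliferative activity, read by sulforhodamine B assay, with a stated time of 3 days (a higher number here means that more compound is needed for the effect, a lower number that less compound is needed), as follows
compound 1 `CCC1=C(O)c2c(oc(-c3ccccc3)cc2=O)C(CC)(CC)C1=O` gives > 236 uM as a limit of the assay
compound 2 `CCC1=C(O)c2c(oc(-c3ccc(C)cc3)cc2=O)C(CC)(CC)C1=O` gives 39.2 uM as a measured number
compound 3 `CCC1=C(O)c2c(oc(-c3ccc(CC(C)C)cc3)cc2=O)C(CC)(CC)C1=O` gives 29.3 uM as a measured number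

Compound 3 has the lowest of the two measured numbers, but its place is not separated from compound 2, since isopropyl in place of hydrogen on a saturated chain carbon bound to an aromatic carbon gives a 1.3-fold lower number from compound 2 to compound 3 (0.13 log units; within the scatter) and stays within the scatter. Compound 4 `CCOc1ccc(-c2cc(=O)c3c(o2)C(CC)(CC)C(=O)C(CC)=C3O)cc1` carries ethoxy in place of isobutyl on an aromatic carbon para to a large group. For the measured compounds named here, two measured steps bear on that carbon. Methyl in place of hydrogen gives an at least 6.0-fold lower number from compound 1 to compound 2 (0.77 log units; beyond the scatter) and isobutyl in place of hydrogen gives an at least 8.0-fold lower number from compound 1 to compound 3 (0.90 log units; beyond the scatter) as steps measured from a limit. Neither step involves ethoxy, so the expectation rests on the two substituted compounds agreeing within the scatter. The estimated step is a 1.2-fold higher number from compound 3 to compound 4 (0.08 log units; within the scatter) in this assay and none beyond the scatter is expected. Compound 4 is expected at 35 uM with an estimated range from 14 uM to 85 uM in this assay.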

Compound 4, concentration for half-maximal effect: > 52.4 uM
Compound 4: only a limit was reported; the forecaster's own chance of this, stated with the estimate: 10%; middle value at least 1.4-fold (0.17 log units) away from the limit.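

In this assay compound 4 gives > 52.4 uM, a limit of the assay and not a number. For the compounds shown here, this is the first group with an oxygen on this aromatic carbon, and unlike methyl and isobutyl it yields no measured number, so a substituent here does not by itself ensure one. Even so, an at least 1.7-fold higher number from compound 3 to compound 4 (0.25 log units; that floor lies within the scatter) and an at least 1.3-fold higher number from compound 2 to compound 4 (0.12 log units; that floor lies within the scatter) give only floors, so ethoxy is not separated from either group, while the step with ethoxy in place of hydrogen joins two limits and cannot be read.

The compounds shown leave open whether the true value of compound 4 lies close to those of compound 2 and compound 3 or far beyond them. They also leave open whether a longer butoxy chain or an amine on this carbon would give a measured number.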